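Amide to Urea Linker Change in Kidney Cancer Cell Growth

The source may report more compounds than this note shows. Statements on the series, on what has been measured and on what is new or still open speak of the compounds shown alone.

Compound 1 `O=C(Nc1cccc(-n2cc(-c3ccncc3)c(-c3ccc(Cl)c(O)c3)n2)c1)Nc1ccc(Cl)c(Cl)c1` gives 14300 nM in a functional assay on CAKI-1 cells (Homo sapiens) for inhibition, read by sulforhodamine B assay, with a stated time of 48 h; on this read-out higher numbers stand for weaker inhibition of growth and lower numbers for stronger inhibition of growth.
Compound 2 `COc1cc(-c2nn(-c3cccc(NC(=O)c4ccc(Cl)c(C(F)(F)F)c4)c3)cc2-c2ccncc2)ccc1Cl` gives only a limit in this assay, > 32500 nM.

Compound 2 therefore sits at the edge of what this assay can report (the limit of > 32500 nM in this assay, at which 1 of the 2 values shown sits); only compound 1 shows a number here. Compound 3 `COc1cc(-c2nn(-c3cccc(NC(=O)Nc4ccc(Cl)c(C(F)(F)F)c4)c3)cc2-c2ccncc2)ccc1Cl` is not yet measured. It differs from compound 2 in one place ((4-chloro-3-(trifluoromethyl)phenyl)amino in place of 4-chloro-3-(trifluoromethyl)phenyl on a carbonyl carbon). Because compound 1 gives 14300 nM, a measurable number is expected for compound 3, and the step of an at least 1.6-fold lower number from compound 2 to compound 3 (0.21 log units; that floor lies within the scatter) is estimated as a modest move toward stronger growth inhibition, only slightly beyond the scatter. Compound 3 is expected to give about 20000 nM, between 8000 nM and 40000 nM.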

Compound 3, concentration for total growth inhibition: 4720 nM
Compound 3: the middle estimate sits 4.2-fold (0.63 log units) above what was measured; the whole stated range lies above it.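

Putting (4-chloro-3-(trifluoromethyl)phenyl)amino in place of 4-chloro-3-(trifluoromethyl)phenyl on the carbonyl carbon, which turns the amide into a urea, gives an at least 6.8-fold lower number from compound 2 to compound 3 (0.83 log units; beyond the scatter) in this assay. This position therefore responds to the change, with stronger inhibition of growth on the urea side. The true size of the step stays unknown because one end of it is a limit and not a number: the limit of > 32500 nM in this assay, at which 1 of the 3 values shown sits.

As far as these compounds go, whether the nitrogen itself matters remains open. The compounds shown do not tell how a methylene group or an oxygen atom in that place would compare.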